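Sulfo for Carboxy in a Rabbit Plasma Series at Its Limit

The compounds below may be only part of what the source reports. "The series", "measured", "known", "first", "only" and "open" are said of these compounds alone.

Compound 1 `CC(C)c1ccc2c(CCCCNS(=O)(=O)c3ccc(Cl)cc3)cc(C(=O)O)c-2cc1` and compound 2 `COc1ccc(S(=O)(=O)NCCCCc2cc(C(=O)O)c3ccc(C(C)C)ccc2-3)cc1` share one core and differ only by a step that the two limits leave unreadable from compound 1 to compound 2. In a functional assay (plasma) for inhibition, with Oryctolagus cuniculus as the target (a higher number here means a weaker inhibitor, a lower number a stronger inhibitor), compound 1 reaches only the limit > 100000 nM. Compound 2 likewise gives only the limit > 100000 nM. Both values sit at the limit of > 100000 nM in this assay, at which 2 of the 2 values shown sit, so the size of that step cannot be read. Compound 3 `COc1ccc(S(=O)(=O)NCCCCc2cc(S(=O)(=O)O)c3ccc(C(C)C)ccc2-3)cc1` differs from compound 2 by sulfo in place of carboxy on an aromatic carbon. Going by the values given here, no measured step bears on this change, and the step of a number no higher from compound 2 to compound 3 (the limit leaves the size open) is therefore expected to be none beyond the scatter. Compound 3 is expected to remain near the limit, estimated at 100000 nM with a range from 30000 nM to 300000 nM.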

Compound 3, half-maximal inhibitory concentration: 64000 nM
Compound 3: the middle estimate sits 1.6-fold (0.19 log units) above what was measured; low and high end bracket the measured number.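

Sulfo in place of carboxy on this aromatic carbon gives an at least 1.5-fold lower number from compound 2 to compound 3 (0.19 log units; that floor lies within the scatter). The true size of the step may be larger, but that cannot be read from a floor. Compound 3 is thus the only compound shown to give a number rather than a limit in this assay: the limit of > 100000 nM in this assay, at which 2 of the 3 values shown sit.

As far as these compounds go, whether sulfo would do the same on the chloro analogue, compound 1, stays open. So does whether a phosphonic acid or a primary amide on that aromatic carbon, or a shorter chain on the sulfonamide, would lower the number further.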